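Methyl for fluoro on the aroyl ring: cytotoxicity outlook

The source may hold more compounds than are shown below. What is called first, only, known or untested is meant among the compounds shown, and "the series" means these compounds.

The measured compounds:
Compound 1, `O=C(/C=C/c1ccc2c(c1)B(O)OC2)c1ccc(F)cc1`, in a toxicity assay on MCF-10A cells (Homo sapiens) for cytotoxicity, read by MTT assay, with a stated time of 48 h; a lower number here means a stronger inhibitor, a higher number a weaker inhibitor: 11800 nM
Compound 2, `Cc1ccc(C(=O)/C=C/c2ccc3c(c2)B(O)OC3)cc1`, in this assay: 8300 nM
Compound 3, `O=C(/C=C/c1ccc2c(c1)B(O)OC2)c1cccc(F)c1`, in this assay: 15800 nM

All three share a core carrying a carbonyl linked through a double-bonded chain to a boron-containing bicyclic unit, and differ only in the aryl group on that carbonyl. Compound 2 differs from compound 1 by methyl in place of fluoro on an aromatic carbon. Compound 3 differs from compound 1 by 3-fluorophenyl in place of 4-fluorophenyl on a carbonyl carbon. The three numbers lie close together: a 1.4-fold lower number from compound 1 to compound 2 (0.15 log units; within the scatter), a 1.3-fold higher number from compound 1 to compound 3 (0.13 log units; within the scatter), and a 1.9-fold higher number from compound 2 to compound 3 (0.28 log units; within the scatter). None of these steps is larger than the usual scatter, so no ordering among the three can be claimed.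

Compound 4, `Cc1cccc(C(=O)/C=C/c2ccc3c(c2)B(O)OC3)c1`, has not yet been measured in this assay. It differs from compound 3 by methyl in place of fluoro on an aromatic carbon. For the measured compounds named here, this is the same kind of change as the one from compound 1 to compound 2, but not the same: in the earlier pair the site is described as para to a large group, whereas here it is meta to a large group.

The earlier instance of this change gave a small step, well within scatter. Compound 4 is therefore expected to sit near compound 3, with an estimated step of a 1.4-fold lower number from compound 3 to compound 4 (0.14 log units; within the scatter), resting on the small size of a 1.4-fold lower number from compound 1 to compound 2 (0.15 log units; within the scatter). For compound 4 in this assay the estimate is 11500 nM, expected to fall between 6000 nM and 22000 nM.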

Compound 4, half-maximal inhibitory concentration: 15900 nM
For compound 4 the middle estimate is 1.4-fold (0.14 log units) below the measured one; measured number inside the range.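

In this assay, methyl in place of fluoro at the site meta to a large group gives a 1.0-fold higher number from compound 3 to compound 4 (0.00 log units; within the scatter), and the two other new comparisons, a 1.9-fold higher number from compound 2 to compound 4 (0.28 log units; within the scatter) and a 1.3-fold higher number from compound 1 to compound 4 (0.13 log units; within the scatter), also stay within the scatter. Set beside the earlier instance of this change, the new step does not differ from it: the same change on two cores in this assay, a 1.4-fold lower number (0.15 log units; within the scatter) from compound 1 to compound 2 and a 1.0-fold higher number (0.00 log units; within the scatter) from compound 3 to compound 4, 1.4-fold (0.16 log units) apart, within the scatter of two such steps This shows that in these two pairs, one with the aryl group 4-fluorophenyl and one with 3-fluorophenyl, swapping fluoro for methyl produced no step that can be told from the scatter, but it does not show that a real effect of the change carries from one core to the other, as neither step is large enough to be followed, and two pairs cannot establish a rule for the series.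

The compounds shown leave open whether an amine, a carboxylic acid or a methoxy group on the aroyl ring would give a step beyond the scatter in this assay. They also leave open how the numbers would respond to a longer chain in place of the double-bonded link, or to a change on the boron-containing bicyclic unit.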